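Shortening the Selenium Chain Across Two Cores

This account rests on a few compounds, and the source may have more. Where it says the series, first, only, none or still open, it means among the compounds named here.

The measured compounds are these. Compound 1 `CCCCC[Se]c1nc(NCc2ccccc2)c2ccccc2n1` reaches only the limit > 100000 nM in an ADME assay on BEAS-2B cells (Homo sapiens) for cytotoxicity, read by MTT assay, with a stated time of 72 h (a lower number here means a stronger inhibitor of growth, a higher number a weaker inhibitor of growth), a limit and not a number. Compound 2 `CCCCC[Se]c1nc(N)c2cccnc2n1` gives 44900 nM in this assay. Compound 3 `C[Se]c1nc(NCc2ccccc2)c2ccccc2n1` gives 37000 nM in this assay.

Compound 3 differs from compound 1 by hydrogen in place of butyl on a saturated chain carbon bound to a selenium atom. That change brought an at least 2.7-fold lower number from compound 1 to compound 3 (0.43 log units; beyond the scatter), although the starting point is only known as the limit of > 100000 nM in this assay, at which 1 of the 3 values shown sits. Compound 2 and compound 3 sit within the scatter of each other, so no order between them can be read. The difference between the core of compound 2 and the core of compound 1 is not broken down here.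

Compound 4 `C[Se]c1nc(N)c2cccnc2n1` has not yet been measured in this assay. It differs from compound 2 by hydrogen in place of butyl on a saturated chain carbon bound to a selenium atom, the same change as from compound 1 to compound 3. Resting on that earlier step, compound 4 is expected to show a 2.5-fold lower number from compound 2 to compound 4 (0.40 log units; beyond the scatter), a similar size of step. The estimate for compound 4 in this assay is therefore 18000 nM, expected to lie between 7000 nM and 55000 nM.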

Compound 4, concentration for total growth inhibition: 90800 nM
Beside the measured number, compound 4's estimate is 5.0-fold (0.70 log units) below it; measured number outside the range, above it.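

On the core of compound 2, hydrogen in place of butyl on a saturated chain carbon bound to a selenium atom, the same difference as pentyl to methyl, brought a 2.0-fold higher number from compound 2 to compound 4 (0.31 log units; beyond the scatter) in this assay. Set beside the earlier step, this change does not carry from one core to the other, not even in direction: the same change on two cores in this assay, an at least 2.7-fold lower number (0.43 log units; beyond the scatter) from compound 1 to compound 3 and a 2.0-fold higher number (0.31 log units; beyond the scatter) from compound 2 to compound 4, at least 5.4-fold (0.73 log units) apart, beyond the scatter of two such steps Compound 1 stands at a limit and not a number, so the full size of the earlier step stays unknown, and two pairs do not show which part of the cores goes with the reversal: the limit of > 100000 nM in this assay, at which 1 of the 4 values shown sits.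

The compounds shown leave open whether a propyl chain, in place of the pentyl or methyl, would fall on the path of either step on each core. They also leave open whether the benzyl group on the amine of compound 1 and compound 3, or the remainder of the core, goes with the difference in direction.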